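Extending the saturated chain of compound 1 by a butyl group

A few compounds are considered here, and "the series" means these few. Any claim that something is new, unique, unknown or untested is made for them only; others in the source may bear on it.

Measured so far:
- compound 1, `CCCCCCCCCCCCC/C=C1\CC(CO)(COC(C)=O)OC1=O`: 5.36
- compound 2, `CCCCCCCCCCCCC/C=C1/C[C@@](CO)(COC(C)=O)OC1=O`: 5.36; 5.36 (2 entries)

Both compounds share the same core and differ only in how the double bond is drawn, and the fact that one of compounds 1 and 2 is drawn with a defined configuration and the other without, at the place where they differ marks that difference. Among the compounds with values here, no step between them is counted here; what the numbers show is that in a physicochemical assay for lipophilicity (on this read-out lower numbers stand for lower lipophilicity and higher numbers for higher lipophilicity), compound 1 gives 5.36 and compound 2 gives 5.36; 5.36 (2 entries), values that sit together. Within the data shown here, compound 1 thus carries the only number in this set that comes as a single reading, and it lies where compound 2 lies.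

The unmeasured compound is compound 3, `CCCCCCCCCCCCCCCCC/C=C1\CC(CO)(COC(C)=O)OC1=O`. The change from compound 1 reads (butyl in place of hydrogen on a saturated chain carbon, ten or more bonds along the chain from a double-bonded chain carbon). Among the measured compounds shown here, since no step between measured compounds is given, the expectation must rest on the nature of the change alone: four carbon atoms are added to a saturated chain, with no donor or acceptor and no charge. Such an addition is expected to raise the reading in this assay well beyond the usual scatter. The step is estimated as a number 1.84 log units higher from compound 1 to compound 3 (beyond the scatter). Compound 3 is therefore expected to give about 7.2, within a range from 6.5 to 7.9.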

Compound 3, partition coefficient: 7.11
For compound 3 the middle estimate is 0.09 log units above the measured one; measured number inside the range.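

In this assay, within the data shown here, putting butyl in place of hydrogen on a saturated chain carbon, ten or more bonds along the chain from a double-bonded chain carbon, gives a number 1.75 log units higher from compound 1 to compound 3 (beyond the scatter), and this is the first step in the set that can be read at all. Compounds 1 and 2 carry the same chain and differ only in how the double bond is drawn, so their matching readings could say nothing about what happens when the chain itself changes; this result shows that this position on the chain does respond, and that a change made of carbon alone, with no hydrogen-bond donors, no hydrogen-bond acceptors and no net charge, is enough to move the reading by a large step. What is on hand about these compounds gives no explanation for the size of this step.

Going by these compounds, with a single step, it remains open whether a propyl group or a longer chain such as octyl at the same place would shift the reading in proportion to its length. On these data alone, it also remains open how an amine or a carboxylic acid placed on this chain would move the reading.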